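Benzimidazole substituent removal in a sulfonylcarbamate series

The source may hold more compounds than are shown below. What is called first, only, known or untested is meant among the compounds shown, and "the series" means these compounds.

Compound 3 `CCCCOC(=O)NS(=O)(=O)c1ccc(CCC)cc1-c1ccc(Cn2c(CCCC)nc3ccccc32)cc1` gives 9.2 nM in an assay on membranes from HEK293 cells for displacement of a labelled ligand from Type-2 angiotensin II receptor (Homo sapiens), read by radioligand binding (on this read-out higher numbers stand for weaker inhibition and lower numbers for stronger inhibition), second highest of the three numbers: its nearest neighbour is compound 1 `CCCCOC(=O)NS(=O)(=O)c1ccc(CCC)cc1-c1ccc(Cn2c(-c3nccs3)nc3ccccc32)cc1` with 5.1 nM, its furthest compound 2 `CCCCOC(=O)NS(=O)(=O)c1ccc(CCC)cc1-c1ccc(Cn2c(-c3ccccc3)nc3ccccc32)cc1` with 590 nM. Compound 4 `CCCCOC(=O)NS(=O)(=O)c1ccc(CCC)cc1-c1ccc(Cn2cnc3ccccc32)cc1` carries hydrogen in place of butyl on an aromatic carbon. All three measured steps vary this same position: a 120-fold higher number from compound 1 to compound 2 (2.06 log units; beyond the scatter), a 1.8-fold higher number from compound 1 to compound 3 (0.26 log units; within the scatter) and a 64-fold lower number from compound 2 to compound 3 (1.81 log units; beyond the scatter). Among the measured compounds shown here, the butyl and 1,3-thiazol-2-yl groups sit close together, while phenyl is far weaker, so the position tolerates some groups and not others; hydrogen has no measured counterpart here. A moderate loss beyond the scatter is expected, a 5.4-fold higher number from compound 3 to compound 4 (0.74 log units; beyond the scatter) in this assay. Compound 4 is therefore estimated at 50 nM, with a range from 8 nM to 400 nM.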

Compound 4, inhibition constant: 29 nM
For compound 4 the middle estimate is 1.7-fold (0.24 log units) above the measured one, and the stated range covers the measured number.
By their numbers in this assay, from the lowest: compounds 1 and 3 (each within the scatter of the next); then compound 4; then compound 2.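

Hydrogen on this carbon gives a modest loss against butyl, a 3.2-fold higher number from compound 3 to compound 4 (0.50 log units; beyond the scatter), and against 1,3-thiazol-2-yl, a 5.7-fold higher number from compound 1 to compound 4 (0.75 log units; beyond the scatter), so both groups improve on the bare position, but only moderately. The bare position still far outperforms phenyl, a 20-fold lower number from compound 2 to compound 4 (1.31 log units; beyond the scatter), which shows that phenyl actively lowers binding here rather than merely failing to add to it. No available evidence accounts for this ordering.

Open, as far as these compounds go, is whether a shorter chain such as methyl recovers the butyl level, and whether an amine is tolerated here.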